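Replacing ethyl with a five-membered ring on the shared core

A few compounds are considered here, and "the series" means these few. Any claim that something is new, unique, unknown or untested is made for them only; others in the source may bear on it.

Measured so far:
compound 1 `COc1cc(-c2cnn3cc(OC)c(C(C)C)nc23)ccn1` — 3800 nM
compound 2 `CCc1nc2c(-c3ccnc(OC)c3)cnn2cc1OC` — 960 nM

In an assay on isolated protein for inhibition of activin receptor type-2A (Homo sapiens), read by 33P incorporation, with a stated time of 20 min, in the presence of a further agent that is not named here (a higher number here means a weaker inhibitor, a lower number a stronger inhibitor), compound 2 gives the lower of the two numbers, and the gap to compound 1 is beyond the usual scatter. Within the data shown here, that single measured step, a 4.0-fold lower number from compound 1 to compound 2 (0.60 log units; beyond the scatter), is the only guide available for the position in question. Compound 3 `COc1cc(-c2cnn3cc(OC)c([C@@H]4COC(C)(C)C4)nc23)ccn1` changes the same position again: a group of 7 heavy atoms (6 carbon, 1 oxygen; one five-membered non-aromatic ring with 1 hetero atom) in place of a group of 2 heavy atoms (2 carbon; no ring), on an aromatic carbon. Among the measured compounds shown here, no measured pair shows an ethyl group giving way to such a ring, so the bearing of the one known step is indirect; it shows only that adding a methyl at this position made the number larger. A group of 7 heavy atoms is a further enlargement, and the expectation is therefore a modest rise in the number for compound 3, a 2.1-fold higher number from compound 2 to compound 3 (0.32 log units; beyond the scatter), although with wide uncertainty. Compound 3 is estimated at 2000 nM, in the range 400 nM to 10000 nM.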

Compound 3, half-maximal inhibitory concentration: 5300 nM
Estimate against measurement, compound 3: 2.7-fold (0.42 log units) below; the measured number falls inside the stated range.
By their numbers in this assay, from the lowest: compound 2; then compounds 1 and 3 (each within the scatter of the next).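

In this assay, the ring-bearing compound sits clearly above the ethyl compound (a 5.5-fold higher number from compound 2 to compound 3 (0.74 log units; beyond the scatter)), so at this position on an aromatic carbon, ethyl is not matched by the five-membered ring with its two extra methyl groups. Against the group at this position on compound 1, the ring gives no readable difference (a 1.4-fold higher number from compound 1 to compound 3 (0.14 log units; within the scatter)), so the rise seen on leaving ethyl does not keep growing with the heavy-atom count across these three compounds. Nothing measured here explains why the number moves at this position.

As far as these compounds go, whether a smaller methyl group, or an amine, would go lower than ethyl remains open. So does the effect of the ring oxygen, which a plain cyclopentyl group would test, and of the opposite stereocentre in the ring.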